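Rat microsomal half-life: adding hydroxy to compound 2

A few compounds are considered here, and "the series" means these few. Any claim that something is new, unique, unknown or untested is made for them only; others in the source may bear on it.

Compound 1 `CC(C)(C)n1nc(Cc2cccc(Cl)c2)c2c(N)ncnc21`: 0.0667 h
Compound 2 `CC(C)n1nc(Cc2cccc(Cl)c2Cl)c2c(N)ncnc21`: 0.117 h

Both values come from an ADME assay on microsomes from liver (Rattus norvegicus) for metabolic stability, read by LC-MS; a higher number here means that the compound lasts longer, a lower number that the compound disappears faster. In this series, compound 2 at 0.117 h lies within the scatter of compound 1 at 0.0667 h, and the two differ in more than one place. Neither value can therefore be read as the effect of a single change.

Compound 3 `CC(C)n1nc(C(O)c2cccc(Cl)c2Cl)c2c(N)ncnc21` is the next point, derived from compound 2 (hydroxy in place of hydrogen on a saturated chain carbon bound to two aromatic carbons). The new group is hydroxy in place of hydrogen on a saturated chain carbon bound to two aromatic carbons. Within the data shown here, no measured pair shows what a single change does in this assay, so any expectation here is weakly anchored. A small rise that stays within the scatter is expected, with a wide margin on either side.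

The expected step is a 1.5-fold higher number from compound 2 to compound 3 (0.16 log units; within the scatter).

For compound 3 the estimated value is 0.17 h, with an expected range of 0.07 h to 0.45 h.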

Compound 3, half-life: 0.337 h
Compound 3: the middle estimate sits 2.0-fold (0.30 log units) below what was measured, and the stated range covers the measured number.
By their numbers in this assay, from the lowest: compounds 1 and 2 (each within the scatter of the next); then compound 3.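

In this assay, among these compounds, hydroxy in place of hydrogen on a saturated chain carbon bound to two aromatic carbons gives a 2.9-fold higher number from compound 2 to compound 3 (0.46 log units; beyond the scatter) and so stands as the first step that can be read as a single change. This chain carbon is therefore a place where one added heavy atom moves the half-life by more than the scatter, which the pair of compound 1 and compound 2, differing in more than one place, could not show. No measurement at hand bears on why the number rises.

Open, from the compounds shown here alone, is whether methoxy, an amine or fluorine on the same carbon would move the half-life as hydroxy does, or whether the step belongs to hydroxy alone. Also open, going by these compounds, is whether hydroxy at this carbon gives a similar step on compound 1.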